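From Isopropyl to Cyclopropyl on the Aromatic Nitrogen

The source may report more compounds than this note shows. Statements on the series, on what has been measured and on what is new or still open speak of the compounds shown alone.

In a functional assay on HCT-116 cells (Homo sapiens) for antiproliferative activity, read by MTT assay, with a stated time of 48 h (a lower number here means a stronger inhibitor, a higher number a weaker inhibitor), compound 1 `COc1ccc(-c2cc3c(cn2)[nH]c(=O)n3-c2cc(OC)c(OC)c(OC)c2)cc1O`, with hydrogen on an aromatic nitrogen, gives 340 nM. Among the measured compounds shown here, with isopropyl there, compound 3 `COc1ccc(-c2cc3c(cn2)n(C(C)C)c(=O)n3-c2cc(OC)c(OC)c(OC)c2)cc1O` gives 6660 nM, the higher of the two exact numbers measured so far. The nearest value is that of compound 1, and the difference is a 20-fold higher number from compound 1 to compound 3 (1.29 log units; beyond the scatter). Compound 2 `CCn1c(=O)n(-c2cc(OC)c(OC)c(OC)c2)c2cc(-c3ccc(OC)c(O)c3)ncc21`, with ethyl there, is recorded only as a limit of the assay, > 20000 nM. Its step is an at least 58-fold higher number from compound 1 to compound 2 (1.76 log units; beyond the scatter), and the step onward is an at least 3.0-fold lower number from compound 2 to compound 3 (0.47 log units; beyond the scatter).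

Compound 4 `COc1ccc(-c2cc3c(cn2)n(C2CC2)c(=O)n3-c2cc(OC)c(OC)c(OC)c2)cc1O` carries cyclopropyl in place of isopropyl on an aromatic nitrogen. The two large steps start from hydrogen, whereas compound 4 keeps a substituent on that nitrogen. The closer guide is therefore the smaller move from compound 2 to compound 3, an at least 3.0-fold lower number from compound 2 to compound 3 (0.47 log units; beyond the scatter). No step beyond the scatter is expected in this assay, although a move in either direction remains possible. The expected step is a 1.1-fold higher number from compound 3 to compound 4 (0.02 log units; within the scatter). The estimated value for compound 4 is 7000 nM, with an expected range of 2000 nM to 20000 nM.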

Compound 4, half-maximal inhibitory concentration: > 20000 nM
Compound 4 ended at the assay's limit (the forecaster's own chance of this, stated with the estimate: 15%); at least 2.8-fold (0.45 log units) between middle value and limit.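

In this assay, the count of atoms alone does not settle the outcome at this position: isopropyl and cyclopropyl each hold 3 carbon, yet exchanging them gives an at least 3.0-fold higher number from compound 3 to compound 4 (0.47 log units; beyond the scatter). Against the unsubstituted nitrogen the change is an at least 58-fold higher number from compound 1 to compound 4 (1.76 log units; beyond the scatter), which leaves compound 3 as the only compound shown with a substituent on this nitrogen that has an exact value. Compound 2 and compound 4 cannot be ordered, and their step cannot be read, because both are recorded as limits: the limit of > 20000 nM in this assay, at which 2 of the 4 values shown sit.

As far as these compounds go, how far the true values of compound 2 and compound 4 lie from that limit remains open. So does the question of whether a methyl group, a longer chain ending in an amine, or a cyclobutyl ring on this nitrogen would give a readable value.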